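Methyl for phenyl on the sulfonamide sulfur

The compounds below may be only part of what the source reports. "The series", "measured", "known", "first", "only" and "open" are said of these compounds alone.

Measured so far:
compound 1 `Nc1cc(-c2cnc3[nH]cc(-c4ccncc4)c3c2)ccc1Cl`; in an assay on isolated protein for inhibition of high affinity nerve growth factor receptor (Homo sapiens), read by 33P incorporation (a higher number here means a weaker inhibitor, a lower number a stronger inhibitor), compound 1 gives 53.7 nM
compound 2 `Nc1cc(NS(=O)(=O)c2ccccc2)cc(-c2cnc3[nH]cc(-c4ccncc4)c3c2)c1`; in this assay compound 2 gives 9.4 nM

Compound 2 holds the lower of the two numbers in this assay; compound 1 sits higher, beyond the scatter. Compound 3 `CS(=O)(=O)Nc1cc(N)cc(-c2cnc3[nH]cc(-c4ccncc4)c3c2)c1` differs from compound 2 by methyl in place of phenyl on a sulfonyl sulfur. Among the compounds with values here, no measured pair shows this change, so its size is not known. The expectation is a modest rise in this assay, a step of a 2.1-fold higher number from compound 2 to compound 3 (0.33 log units; beyond the scatter), close to the edge of the scatter. Compound 3 is estimated at 20 nM, range 7 nM to 60 nM.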

Compound 3, half-maximal inhibitory concentration: 33.8 nM
Compound 3: middle estimate off by 1.7-fold (0.23 log units), on the low side; the measured number falls inside the stated range.
By their numbers in this assay, from the lowest: compound 2; then compounds 3 and 1 (each within the scatter of the next).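

In this assay, methyl in place of phenyl on the sulfonyl sulfur gives a 3.6-fold higher number from compound 2 to compound 3 (0.56 log units; beyond the scatter), so this position responds to the change and the step favours phenyl. The phenyl ring is not essential, however: compound 3, with methyl and no ring, still gives 33.8 nM as an inhibitor. Nothing available explains the size of this step.

As far as these compounds go, whether the ring or simply a larger group is what counts remains open. An ethyl group, a longer chain, a benzyl group or a pyridine ring on the sulfur could separate these readings.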